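Adding a Methoxy Group to the Core: Permeability Outlook

The source may report more compounds than this note shows. Statements on the series, on what has been measured and on what is new or still open speak of the compounds shown alone.

Compound 1, `Cc1cc(C)cc(NC(=O)Cn2ccc(=O)c3ccccc32)c1`: 450 nm/s
Compound 2, `Cc1cc(C)cc(NC(=O)Cn2ccc(=O)c3ccc(Cl)cc32)c1`: 260 nm/s

In a physicochemical assay for permeability, using PAMPA (on this read-out higher numbers stand for higher permeability and lower numbers for lower permeability), compound 1 gives the highest of these two numbers, but the gap a 1.7-fold lower number from compound 1 to compound 2 (0.24 log units; within the scatter) lies within the scatter, so the two cannot be ranked. Compound 3, `COc1ccc2c(c1)c(=O)ccn2CC(=O)Nc1cc(C)cc(C)c1`, differs from compound 1 by methoxy in place of hydrogen on an aromatic carbon. Within the data shown here, the one measured step, chloro in place of hydrogen on an aromatic carbon of the same core, changed this assay little, so for this second substitution on the same ring no step beyond the scatter is expected, with a 1.2-fold lower number from compound 1 to compound 3 (0.07 log units; within the scatter). For compound 3 the expected value is 380 nm/s, in a range from 190 nm/s to 760 nm/s.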

Compound 3, apparent permeability: 190 nm/s
Estimate against measurement, compound 3: 2.0-fold (0.30 log units) above, and the stated range covers the measured number.
By their numbers in this assay, from the lowest: compounds 3, 2 and 1 (each within the scatter of the next, the first and the last beyond it).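

In this assay, methoxy in place of hydrogen on an aromatic carbon of the shared core gives a 2.4-fold lower number from compound 1 to compound 3 (0.37 log units; beyond the scatter), a modest step. Among these compounds, this is the first step on this ring that lies beyond the scatter, while the chloro step, a 1.7-fold lower number from compound 1 to compound 2 (0.24 log units; within the scatter), stays within it. Nothing available explains this difference between the two groups. Going by these compounds, whether an ethoxy group or an amine on this same carbon would give a step of similar size remains open. So does whether methoxy would give the same step on another carbon of this ring.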